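From 2-acetylethenyl to 2-cyanoethenyl: working notes on a small series

The source may report more compounds than this note shows. Statements on the series, on what has been measured and on what is new or still open speak of the compounds shown alone.

Measured in a functional assay on HeLa cells (Homo sapiens) for inhibition; on this read-out lower numbers stand for stronger inhibition and higher numbers for weaker inhibition:
- compound 1 `O=C/C=C/n1c(=O)ccn([C@H]2C[C@H](O)[C@@H](CO)O2)c1=O`, 15000 nM
- compound 2 `CC(=O)/C=C/n1c(=O)ccn([C@H]2C[C@H](O)[C@@H](CO)O2)c1=O`, 6000 nM

Among the measured compounds shown here, of the two measured compounds, compound 2 has the lower number, at 6000 nM, and compound 1 is its only neighbour. Compound 3 `N#C/C=C/n1c(=O)ccn([C@H]2C[C@H](O)[C@@H](CO)O2)c1=O` has not yet been measured in this assay. The change is cyano in place of acetyl on a double-bonded chain carbon bound to a double-bonded chain carbon.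

For the measured compounds named here, only one measured step bears on this, and only indirectly: a 2.5-fold lower number from compound 1 to compound 2 (0.40 log units; beyond the scatter). That step is modest and swaps hydrogen for methyl on a carbonyl carbon, whereas the coming change removes the carbonyl group altogether. Going by the values given here, no measured compound yet carries the cyano group, so the direction is weakly held. A step of similar modest size is expected, leaning toward a higher number, and a result within the scatter would not surprise. The expected step is a 1.5-fold higher number from compound 2 to compound 3 (0.18 log units; within the scatter). The estimated value for compound 3 is 9000 nM, with an expected range of 3000 nM to 27000 nM.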

Compound 3, half-maximal inhibitory concentration: 100000 nM
Compound 3: middle estimate off by 11-fold (1.05 log units), on the low side, outside the stated range (above it).
By their numbers in this assay, from the lowest: compound 2; then compound 1; then compound 3.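

In this assay, this place on a double-bonded chain carbon bound to a double-bonded chain carbon proves far less tolerant of change than the earlier pair suggested: cyano in place of acetyl gives a 17-fold higher number from compound 2 to compound 3 (1.22 log units; beyond the scatter) and is a large step, well beyond the modest 2.5-fold lower number from compound 1 to compound 2 (0.40 log units; beyond the scatter) seen between the two carbonyl groups. Cyano in place of formyl gives a 6.7-fold higher number from compound 1 to compound 3 (0.82 log units; beyond the scatter) in the same direction, so in these three compounds both groups with a carbonyl stand at lower numbers than the nitrile, and no compound shown goes against this. Nothing available explains why the 2-cyanoethenyl compound stands so far from the other two.

Three compounds cannot show whether the carbonyl itself matters or whether the nitrile is a poor fit for some other reason; a methyl ester, a carboxylic acid or a primary amide at this place would help separate the two readings. From the compounds shown here alone, whether the gain from formyl to acetyl continues also stays open, and a longer chain on the ketone, such as propionyl, would test this.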